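This account rests on a few compounds, and the source may have more. Where it says the series, first, only, none or still open, it means among the compounds named here.

Of the compounds shown here, two that share one core have been measured. Going by the values given here, compound 1 `CCC(C)=C1C(=O)N(c2ccc(Cl)cc2)N(c2ccc(Cl)cc2)C1=O` is the first; in a functional assay on ECa-109 cells (Homo sapiens) for cytotoxicity, read by MTT assay, with a stated time of 72 h (a higher number here means a weaker inhibitor, a lower number a stronger inhibitor), compound 1 gives 41100 nM. Compound 2 `COc1cccc(C=C2C(=O)N(c3ccc(Cl)cc3)N(c3ccc(Cl)cc3)C2=O)c1O` carries a 2-hydroxy-3-methoxyphenyl on a double-bonded chain carbon bound to a double-bonded ring carbon, and in this assay compound 2 gives 39000 nM. Compound 2 has the lowest of the two numbers, but its nearest neighbour, compound 1, lies within the usual scatter of the method, so the two cannot be told apart on these data.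

Compound 3 `O=C1C(=Cc2ccco2)C(=O)N(c2ccc(Cl)cc2)N1c1ccc(Cl)cc1` has not yet been measured. It differs from compound 2 in a single place: furan-2-yl in place of 2-hydroxy-3-methoxyphenyl on a double-bonded chain carbon bound to a double-bonded ring carbon. Among the compounds with values here, no measured pair shows what such an exchange does, so the size of the step rests on the two values alone. Since compound 1 and compound 2 sit so close together despite carrying quite different groups at that place, the step is expected to be small, a 1.2-fold higher number from compound 2 to compound 3 (0.06 log units; within the scatter), with no direction beyond the scatter. Compound 3 is therefore expected to give 45000 nM in this assay, with a range from 15000 nM to 130000 nM.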

Compound 3, half-maximal inhibitory concentration: 14300 nM
Compound 3: the middle estimate sits 3.1-fold (0.50 log units) above what was measured, and the stated range ends above it.
By their numbers in this assay, from the lowest: compound 3; then compounds 2 and 1 (each within the scatter of the next).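

The place on a double-bonded chain carbon bound to a double-bonded ring carbon proves able to shift the result: within this assay the exchange of 2-hydroxy-3-methoxyphenyl for furan-2-yl brings a 2.7-fold lower number from compound 2 to compound 3 (0.44 log units; beyond the scatter) and so gives the first difference on this core that stands clear of the scatter. This one exchange changes several things together, as the group that leaves has 9 heavy atoms, a six-membered aromatic ring of carbon only and 1 hydrogen-bond donor, while the group that enters has 5 heavy atoms, a five-membered aromatic ring with 1 hetero atom and 0 hydrogen-bond donors. No measurement at hand explains the step or ties it to any one of these differences.

As far as these compounds go, it remains open whether the lower number follows from the five-membered ring, its oxygen, or the absence of the hydroxyl and methoxy groups. A plain phenyl, a 2-hydroxyphenyl or a thiophen-2-yl at this same place would help to pull these apart, and any such comparison would still speak only for this core and these cells.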